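Swapping a halogenated phenyl for a pyridinyl-ethyl chain

The compounds below may be only part of what the source reports. "The series", "measured", "known", "first", "only" and "open" are said of these compounds alone.

In a functional assay on U-251 cells (Homo sapiens) for inhibition, read by sulforhodamine B assay, with a stated time of 48 h (a higher number here means a weaker inhibitor of growth, a lower number a stronger inhibitor of growth), compound 3 `Clc1ccc(Br)cc1Cn1cc(CCCOc2cccc3cccnc23)nn1` gives 8.7 ug/mL, the lowest of the two numbers in hand; compound 2 `Fc1ccc(Cn2cc(CCCOc3cccc4cccnc34)nn2)cc1` gives 20.7 ug/mL, with a 2.4-fold lower number from compound 2 to compound 3 (0.38 log units; beyond the scatter). For compound 1 `Ic1ccc(Cn2cc(CCCOc3cccc4cccnc34)nn2)cc1` only a limit is known, > 250 ug/mL. Compound 4 `c1cncc(CCCn2cc(CCCOc3cccc4cccnc34)nn2)c1` is not yet measured; it differs from compound 3 by 2-(pyridin-3-yl)ethyl in place of 5-bromo-2-chlorophenyl on a saturated chain carbon bound to an aromatic nitrogen. The measured steps all alter halogens on a phenyl ring: an at least 12-fold lower number from compound 1 to compound 2 (1.08 log units; beyond the scatter) and an at least 28-fold lower number from compound 1 to compound 3 (1.45 log units; beyond the scatter) were large, a 2.4-fold lower number from compound 2 to compound 3 (0.38 log units; beyond the scatter) modest. None exchanges that ring for a 2-(pyridin-3-yl)ethyl chain, and both measured numbers came from halogenated phenyl rings, so the expectation is uncertain. A higher number is expected for compound 4, a 5.2-fold higher number from compound 3 to compound 4 (0.71 log units; beyond the scatter), with an estimate in this assay of 45 ug/mL and a range from 12 ug/mL to 160 ug/mL.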

Compound 4, concentration for 50% growth inhibition: 25.1 ug/mL
For compound 4 the middle estimate is 1.8-fold (0.25 log units) above the measured one; the range from low to high includes it.
By their numbers in this assay, from the lowest: compound 3; then compounds 2 and 4 (each within the scatter of the next). At a limit, above all of these: compound 1.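

The earlier compounds shown here carried only halogenated phenyl rings at this place, but a halogen-free 2-(pyridin-3-yl)ethyl still inhibits growth in this assay, with a 1.2-fold higher number from compound 2 to compound 4 (0.08 log units; within the scatter) and so no real separation. The 5-bromo-2-chlorophenyl group stays ahead, with a 2.9-fold higher number from compound 3 to compound 4 (0.46 log units; beyond the scatter) for this change. Among the compounds shown here, the third step rests on a limit of the assay and is only a bound, an at least 9.9-fold lower number from compound 1 to compound 4 (0.99 log units; beyond the scatter), as the one capped value shows: the limit of > 250 ug/mL in this assay, at which 1 of the 4 values shown sits.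

As far as these compounds go, whether an amine or a carboxylic acid in place of the pyridin-3-yl ring, or a longer chain, would move the number stays open.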